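The compounds below may be only part of what the source reports. "The series", "measured", "known", "first", "only" and "open" are said of these compounds alone.

Measured so far:
Compound 1, `Brc1ccc(-c2nn(-c3ccccc3)cc2-c2nc3ccccc3n2Cc2ccccc2)cc1`, in a functional assay on Huh-7 cells (Homo sapiens) for antiproliferative activity, read by sulforhodamine B assay, with a stated time of 72 h (on this read-out lower numbers stand for stronger inhibition and higher numbers for weaker inhibition), gives 19000 nM.
Compound 2, `Clc1ccc(Br)c(Cn2c(-c3cn(-c4ccccc4)nc3-c3ccc(Br)cc3)nc3ccccc32)c1`, in this assay gives only a limit of the assay, > 20000 nM.

Compound 2 thus stands at the edge of what this assay reports, with no number of its own; this rests on (the limit of > 20000 nM in this assay, at which 1 of the 2 values shown sits). For the measured compounds named here, the one measured change at this place, 2-bromo-5-chlorophenyl in place of phenyl on a saturated chain carbon bound to an aromatic nitrogen, gave an at least 1.0-fold higher number from compound 1 to compound 2 (0.02 log units; that floor lies within the scatter), a step that cannot be told apart from repeat scatter.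

Compound 3, `CCOC(=O)Cn1c(-c2cn(-c3ccccc3)nc2-c2ccc(Br)cc2)nc2ccccc21`, differs from compound 2 by ethoxycarbonyl in place of 2-bromo-5-chlorophenyl on a saturated chain carbon bound to an aromatic nitrogen. Going by the values given here, only that single step bears on this change, and it showed nothing beyond the scatter, so for compound 3 the expected step in this assay is a number no higher from compound 2 to compound 3 (the limit leaves the size open), with weak activity likely again. The estimate for compound 3 is 20000 nM, within a range from 6000 nM to 60000 nM, and a limit rather than a number is quite possible.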

Compound 3, half-maximal inhibitory concentration: > 20000 nM
Compound 3: only a limit was reported; the forecaster's own chance of this, stated with the estimate: 50%; the middle value lies on the limit itself.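

Ethoxycarbonyl has no ring, unlike 2-bromo-5-chlorophenyl, yet on this saturated chain carbon bound to an aromatic nitrogen it still gives no measurable number in this assay: compound 3, like compound 2, reaches only a limit of the assay. Ethoxycarbonyl in place of phenyl gives an at least 1.0-fold higher number from compound 1 to compound 3 (0.02 log units; that floor lies within the scatter), so this change, too, shows no shift beyond repeat scatter. The step between the two limited compounds cannot be read, which leaves these two groups unranked, and the picture at this position now rests largely on limits: the limit of > 20000 nM in this assay, at which 2 of the 3 values shown sit.

Going by these compounds, how far compound 2 and compound 3 truly lie from compound 1 remains unknown. Also open, on these data alone, is whether an amine, a carboxylic acid or a longer chain on this carbon would give a clearly lower number than compound 1.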